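The compounds below may be only part of what the source reports. "The series", "measured", "known", "first", "only" and "open" are said of these compounds alone.

Compound 2, `O=S(=O)(/C=C/c1ccc(O)c(O)c1)CC1CC1`, in a functional assay, read by fluorescence and spectrophotometry, with a stated time of 1 h (a higher number here means that more compound is needed for the effect, a lower number that less compound is needed), gives 10500 nM. Compound 1, `CCCCCCCCCCCCS(=O)(=O)/C=C/c1ccc(O)c(O)c1`, gives 8500 nM, and compound 3, `O=S(=O)(/C=C/c1ccc(O)c(O)c1)CCCCCCCO`, gives 5900 nM, so both numbers lie within the usual scatter of that of compound 2. Compound 4 is `CCCCCCCCS(=O)(=O)/C=C/c1ccc(O)c(O)c1`; it differs from compound 2 in that (heptyl in place of cyclopropyl on a saturated chain carbon bound to a sulfonyl sulfur). For the measured compounds named here, two measured steps bear on this. The step of a 1.8-fold lower number from compound 2 to compound 3 (0.25 log units; within the scatter) replaces the same cyclopropyl at the same place, and the step of a 1.4-fold lower number from compound 1 to compound 3 (0.16 log units; within the scatter) trades chain length for a hydroxy on a long sulfonyl chain; neither moves the number beyond the scatter. A step in this assay of no more than the scatter is therefore expected, a 1.4-fold lower number from compound 2 to compound 4 (0.15 log units; within the scatter). Compound 4 is thus estimated at 7500 nM, with a range of 3500 nM to 16000 nM.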

Compound 4, half-maximal effective concentration: 6400 nM
Compound 4: the middle estimate sits 1.2-fold (0.07 log units) above what was measured, and the stated range covers the measured number.
By their numbers in this assay, from the lowest: compounds 3, 4, 1 and 2 (each within the scatter of the next).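

In this assay, heptyl in place of cyclopropyl on a saturated chain carbon bound to a sulfonyl sulfur gives a 1.6-fold lower number from compound 2 to compound 4 (0.22 log units; within the scatter), so here an open chain and the three-membered ring are not told apart. Swapping methyl for hydroxy gives a 1.1-fold higher number from compound 3 to compound 4 (0.04 log units; within the scatter), and shortening the chain, hydrogen in place of butyl, gives a 1.3-fold lower number from compound 1 to compound 4 (0.12 log units; within the scatter), so neither change at the chain's far end separates these compounds. No measurement on hand accounts for these small steps.

On these data alone, whether an amine or a carboxylic acid at the chain end, or a chain longer than that of compound 1, would move the number beyond the scatter remains open.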